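Notes on a pyridazinyl amide series: compound 4

The source may hold more compounds than are shown below. What is called first, only, known or untested is meant among the compounds shown, and "the series" means these compounds.

Within the data shown here, compound 3 `O=C(Nc1ccnnc1)c1cc(N2CCCC2)ccc1OCc1ccccc1` gives 6.1 in a physicochemical assay for lipophilicity, at pH 7.4 (a lower number here means a more polar compound, a higher number a more lipophilic compound), and stands highest of the three numbers so far; its nearest neighbour is compound 1 `CN1CC2(C1)CN(c1ccc(OCc3ccccc3)c(C(=O)Nc3ccnnc3)c1)C2` with 2, and compound 2 `O=C(Nc1ccnnc1)c1cc(N2CCNCC2)ccc1OCc1ccccc1` with 1.9 is furthest away. Both steps onto compound 3 are large: a number 4.10 log units higher from compound 1 to compound 3 (beyond the scatter) and a number 4.20 log units higher from compound 2 to compound 3 (beyond the scatter), whereas a number 0.10 log units lower from compound 1 to compound 2 (within the scatter). Compound 4 `CN1CCC(c2ccc(OCc3ccccc3)c(C(=O)Nc3ccnnc3)c2)CC1` carries 1-methylpiperidin-4-yl in place of pyrrolidin-1-yl on an aromatic carbon. Among the measured compounds shown here, no measured step swaps pyrrolidin-1-yl for this exact group, so the bearing is indirect. Both large steps onto compound 3 start from compounds whose ring groups hold more nitrogen than pyrrolidin-1-yl, and of these the group of 8 heavy atoms in compound 1, which gives 2, resembles the entering 1-methylpiperidin-4-yl most in having no hydrogen-bond donor. A large downward step is therefore expected in this assay, namely a number 3.30 log units lower from compound 3 to compound 4 (beyond the scatter). For compound 4 the estimate in this assay is 2.8, with a range of 1.8 to 3.8.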

Compound 4, distribution coefficient: 2.3
Compound 4: middle estimate off by 0.50 log units, on the high side, within the range that was stated.
By their numbers in this assay, from the lowest: compounds 2, 1 and 4 (each within the scatter of the next, the first and the last beyond it); then compound 3.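

In this assay, the step of a number 3.80 log units lower from compound 3 to compound 4 (beyond the scatter) is large even though the leaving pyrrolidin-1-yl and the entering 1-methylpiperidin-4-yl both count 0 hydrogen-bond donors, 1 hydrogen-bond acceptor and no net charge, so a large change at this position does not require a difference in those counts. With a number 0.30 log units higher from compound 1 to compound 4 (within the scatter) and a number 0.40 log units higher from compound 2 to compound 4 (beyond the scatter) the other two steps are far smaller, and among the four groups shown pyrrolidin-1-yl alone stands apart. Nothing available explains the size of the large step.

The change alters ring size and heavy-atom count together, so neither can be credited with the step on its own. On these data alone, how piperidin-1-yl or morpholin-4-yl would read on this aromatic carbon remains open.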